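The source may report more compounds than this note shows. Statements on the series, on what has been measured and on what is new or still open speak of the compounds shown alone.

Of the compounds shown here, three of a shared core have been measured in a functional assay on RXF 393 cells (Homo sapiens) for inhibition, read by sulforhodamine B assay, with a stated time of 48 h, tested at 10 uM; a lower number here means a stronger effect, a higher number a weaker effect of the compound at the concentration tested. Compound 1 `COc1cc(Cl)cc(-c2nn(-c3cccc(NC(=O)Nc4ccc(Cl)c(C(F)(F)F)c4)c3)cc2-c2ccncc2)c1` carries a urea on the aniline; in this assay compound 1 gives -30%. Compound 2 `COc1cc(Cl)cc(-c2nn(-c3cccc(NC(=O)c4cc(C(F)(F)F)cc(C(F)(F)F)c4)c3)cc2-c2ccncc2)c1` carries an amide instead, and in this assay compound 2 gives 67.7%. Compound 3 `COc1cc(Cl)cc(-c2nn(-c3cccc(NC(=O)c4ccc(Cl)c(Cl)c4)c3)cc2-c2ccncc2)c1` is also an amide, and in this assay compound 3 gives 59.2%. On these numbers compound 3 stands second highest of three: its nearest neighbour is compound 2, a number within the scatter, and its furthest is compound 1, a number beyond the scatter. Going by the values given here, the one single-point step measured so far, a number 89.2 percentage points higher from compound 1 to compound 3 (beyond the scatter), is large, but it concerns the exchange of a urea for an amide, not the change now at hand.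

Compound 4 `COc1cc(Cl)cc(-c2nn(-c3cccc(NC(=O)c4cccc(C(F)(F)F)c4)c3)cc2-c2ccncc2)c1` differs from compound 3 in one place: 3-(trifluoromethyl)phenyl in place of 3,4-dichlorophenyl on a carbonyl carbon. Among the compounds with values here, no measured step covers this exchange directly. Both amides already measured, compound 2 and compound 3, sit within the scatter of each other, so for a third amide with a closely related aryl group a step within the scatter is expected in this assay, and the estimated step is a number 4.2 percentage points lower from compound 3 to compound 4 (within the scatter). Compound 4 is therefore expected to give about 55% in this assay, with a range from 25% to 80%.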

Compound 4, a percentage reported as activity, at one concentration (the size of the read-out at that concentration, not a potency): 40.5%
Compound 4: middle estimate off by 14.5 percentage points, on the high side; the range from low to high includes it.
By their numbers in this assay, from the lowest: compound 1; then compound 4; then compounds 3 and 2 (each within the scatter of the next).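

Among the amides, the aryl group on the carbonyl carbon matters in this assay: the exchange of 3,4-dichlorophenyl for 3-(trifluoromethyl)phenyl gives a stronger effect at the concentration tested (a number 18.7 percentage points lower from compound 3 to compound 4 (beyond the scatter)), so amides at this position do not all read alike. Hydrogen in place of one trifluoromethyl on an aromatic carbon points the same way (a number 27.2 percentage points lower from compound 2 to compound 4 (beyond the scatter)), so among these three amides the aryl group of compound 4 stands apart from the two others, which lie within the scatter of each other. The urea keeps a clear lead over this amide (a number 70.5 percentage points higher from compound 1 to compound 4 (beyond the scatter)), and nothing at hand explains either the amide differences or that lead.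

The compounds shown leave open how much of that lead belongs to the urea itself and how much to its 4-chloro-3-(trifluoromethyl)phenyl group, a question that a urea carrying 3-(trifluoromethyl)phenyl would address. They also leave open how an amide would read with a plain phenyl ring, or with an amine or a carboxylic acid on that ring.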